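This account rests on a few compounds, and the source may have more. Where it says the series, first, only, none or still open, it means among the compounds named here.

Compound 1, `COc1cc(Br)ccc1Nc1cc(NC(=O)Nc2c(Cl)cccc2Cl)ncn1`, gives the lowest number of the three compounds measured in a functional assay on HCC827 cells (Homo sapiens) for inhibition, read by MTT assay, with a stated time of 48 h, tested at 10 uM (a higher number here means more inhibition at the concentration tested (going by the name of the read-out), a lower number less inhibition), where compound 1 gives 42.7%. Its nearest neighbour on this read-out is compound 2, `CCc1cccc(Nc2cc(NC(=O)Nc3cc(OC)cc(OC)c3)ncn2)c1`, which in this assay gives 52.6%, a result that lies within the usual scatter of compound 1 and so cannot be separated from it. The furthest is compound 3, `COc1ccc(C(F)(F)F)cc1Nc1cc(NC(=O)Nc2c(Cl)cccc2Cl)ncn1`, which in this assay gives 68.7%, a number beyond the scatter above compound 1.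

The unmeasured compound 4, `Cc1ccc(Nc2cc(NC(=O)Nc3c(Cl)cccc3Cl)ncn2)cc1C`, shares the core of compound 1 and keeps the urea with the 2,6-dichlorophenyl group; it differs in one place: 3,4-dimethylphenyl in place of 4-bromo-2-methoxyphenyl on a nitrogen on an aromatic ring. Among the measured compounds shown here, no measured pair isolates such a change, so its effect in this assay is unknown. Nothing among the three measured compounds shows a reason for a large move in either direction, and a modest rise at most is expected, one likely within the scatter.

Compound 4 is therefore expected to give about 50% in this assay, with a range from 30% to 72%, a step of a number 7.3 percentage points higher from compound 1 to compound 4 (within the scatter).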

Compound 4, a percentage reported as inhibition, at one concentration (the size of the read-out at that concentration, not a potency): 84.3%
For compound 4 the middle estimate is 34.3 percentage points below the measured one, outside the stated range (above it).
By their numbers in this assay, from the lowest: compounds 1 and 2 (each within the scatter of the next); then compound 3; then compound 4.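

In this assay, the group on a nitrogen on an aromatic ring turns out to be able to shift the number substantially: with the core and the urea bearing the 2,6-dichlorophenyl group unchanged, 3,4-dimethylphenyl in place of 4-bromo-2-methoxyphenyl brings a number 41.6 percentage points higher from compound 1 to compound 4 (beyond the scatter). Among the compounds shown here, the earlier compounds offered no comparison that isolated a single place, so this is the first direct sign that this position matters for the read-out. Nothing measured here accounts for the rise, and its cause remains unknown.

Going by these compounds, the whole group changes at once, so it remains open whether the loss of the bromine, the loss of the methoxy or the arrival of the methyl groups carries the step. On these data alone, how this position would respond to an amine or a carboxylic acid on the phenyl ring also remains open.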